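Hydroxamate sulfamides: aryl change on the unsaturated ring

A few compounds are considered here, and "the series" means these few. Any claim that something is new, unique, unknown or untested is made for them only; others in the source may bear on it.

Measured compounds:
compound 1, `O=C(NO)[C@H]1CCCCN1S(=O)(=O)N1CC=C(c2ccc(Cl)cc2)CC1` — 430 nM; 480 nM (2 entries)
compound 2, `O=C(NO)[C@H]1CCCCN1S(=O)(=O)N1CC=C(c2ccccc2)CC1` — 240 nM
compound 3, `COc1ccc(C2=CCN(S(=O)(=O)N3CCCC[C@@H]3C(=O)NO)CC2)cc1` — 15000 nM

In a functional assay on MONO-MAC-6 cells (Homo sapiens) for inhibition (a lower number here means a stronger inhibitor, a higher number a weaker inhibitor), compound 3 stands at the weak end of the series, with the highest number measured; its nearest neighbour is compound 2, and the step of a 63-fold higher number from compound 2 to compound 3 (1.80 log units; beyond the scatter) is large and well beyond the scatter. Compound 1 sits close to compound 2 on the numbers shown, and its repeat entries the several entries of compound 1 in this assay, 430 nM; 480 nM (2 entries) agree with one another.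

Compound 4, `O=C(NO)[C@H]1CCCCN1S(=O)(=O)N1CC=C(c2ccc(F)c(F)c2)CC1`, is not yet measured. It differs from compound 3 in one place: 3,4-difluorophenyl in place of 4-methoxyphenyl on a double-bonded ring carbon.

Going by the values given here, the only measured step that bears on this change is a 63-fold higher number from compound 2 to compound 3 (1.80 log units; beyond the scatter), which shows that adding the methoxy group costs potency heavily. Removing that methoxy group again, as in compound 4, is expected to reverse much of that loss; compound 1 shows that a shared core carrying an aromatic ring without the methoxy group stays in the region of compound 2. The step of a 33-fold lower number from compound 3 to compound 4 (1.52 log units; beyond the scatter) is therefore expected to be large and toward a lower number.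

For compound 4 the estimated value in this assay is 450 nM, in the range 150 nM to 1500 nM.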

Compound 4, half-maximal inhibitory concentration: 1200 nM
Compound 4: the middle estimate sits 2.7-fold (0.43 log units) below what was measured; the measured number falls inside the stated range.
By their numbers in this assay, from the lowest: compound 2; then compound 4; then compound 3.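

In this assay, 3,4-difluorophenyl in place of 4-methoxyphenyl on the double-bonded ring carbon gives a 13-fold lower number from compound 3 to compound 4 (1.10 log units; beyond the scatter), so the heavy loss seen with 4-methoxyphenyl is not shared by every substituted aryl group at this position. The recovery is only partial, however: a 5.0-fold higher number from compound 2 to compound 4 (0.70 log units; beyond the scatter) leaves the unsubstituted phenyl of compound 2 ahead of the 3,4-difluorophenyl of compound 4, which shows that this substitution also carries a cost, though a much smaller one than 4-methoxyphenyl. Nothing measured here gives a reason for either step.

The compounds shown do not reveal whether the cost in compound 4 comes from one fluorine or from both, a question that 3-fluorophenyl and 4-fluorophenyl groups at this position would address. They also leave open whether the large loss in compound 3 belongs to the oxygen of the methoxy group, which a comparison with 4-methylphenyl or 4-hydroxyphenyl would test in this series.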